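This account rests on a few compounds, and the source may have more. Where it says the series, first, only, none or still open, it means among the compounds named here.

Working notes on a short series built on the core of compound 1 `COC[C@H]1OC(n2c(Cl)nc3cc(Cl)c(Cl)cc32)[C@H](O)[C@@H]1O`, varied on a saturated chain carbon bound to a saturated ring carbon. In a functional assay on L1210 cells (Mus musculus) (a higher number here means a weaker inhibitor, a lower number a stronger inhibitor), compound 1 gives 60000 nM, compound 2 `CCOC[C@H]1OC(n2c(Cl)nc3cc(Cl)c(Cl)cc32)[C@H](O)[C@@H]1O` gives 59000 nM, and compound 3 `O[C@@H]1[C@@H](CBr)OC(n2c(Cl)nc3cc(Cl)c(Cl)cc32)[C@@H]1O` gives 100000 nM. Compound 3, the bromo member, does not separate from the other two: a 1.7-fold higher number from compound 1 to compound 3 (0.22 log units; within the scatter), and a 1.7-fold higher number from compound 2 to compound 3 (0.23 log units; within the scatter).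

The next structure is compound 4 `[N-]=[N+]=NC[C@H]1OC(n2c(Cl)nc3cc(Cl)c(Cl)cc32)[C@H](O)[C@@H]1O`, with azido in place of bromo on a saturated chain carbon bound to a saturated ring carbon. Among the compounds with values here, no azido compound has been measured yet, so the nearest evidence is the two steps to bromo at this same place, both within the scatter. The step from methoxy to ethoxy at this place also stays inside it: a 1.0-fold lower number from compound 1 to compound 2 (0.01 log units; within the scatter). All three groups tested here therefore give values within the scatter of each other. No step beyond the scatter is expected in this assay, and the data support no firm direction. The expected change is small: a 1.4-fold lower number from compound 3 to compound 4 (0.15 log units; within the scatter). For compound 4 the estimated value is 70000 nM, with an expected range of 30000 nM to 150000 nM.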

Compound 4, half-maximal inhibitory concentration: 80000 nM
Estimate against measurement, compound 4: 1.1-fold (0.06 log units) below, and the stated range covers the measured number.
By their numbers in this assay, from the lowest: compounds 2, 1, 4 and 3 (each within the scatter of the next).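

Azido is a larger replacement for bromo, with three nitrogen atoms in place of one bromine atom, yet in this assay the step remains inside the scatter: a 1.3-fold lower number from compound 3 to compound 4 (0.10 log units; within the scatter). The comparisons with the two ether members read the same way, with a 1.4-fold higher number from compound 2 to compound 4 (0.13 log units; within the scatter) and a 1.3-fold higher number from compound 1 to compound 4 (0.12 log units; within the scatter), so all four groups now tested on this saturated chain carbon bound to a saturated ring carbon lie within the scatter of each other and cannot be ranked. Nothing available explains why these groups read alike in this assay.

Whether an amine, a carboxylic acid or a longer chain at this place would produce a step beyond the scatter remains open, since the four groups shown do not settle how far this insensitivity extends. From the compounds shown here alone, all four compounds also share the core of compound 1, so it is equally open whether this position would stay as insensitive to replacement on a different core.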